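The source may report more compounds than this note shows. Statements on the series, on what has been measured and on what is new or still open speak of the compounds shown alone.

Measured so far:
- compound 1 `O=S(=O)(c1cccc(C(F)(F)F)c1)N1CCc2ccc(OCc3c(F)cccc3Cl)cc21`: 80 nM
- compound 2 `O=S(=O)(c1cccc(C(F)(F)F)c1)N1CCc2ccc(-c3cc(F)cc(OC(F)F)c3)cc21`: 1480 nM

In a physicochemical assay for solubility, read by LC-MS, in phosphate buffer, measured as kinetic solubility, with a stated time of 120 min, at pH 7.46, tested at 100 uM (a lower number here means a less soluble compound, a higher number a more soluble compound), compound 2 has the higher of the two numbers, at 1480 nM, and compound 1 gives 80 nM. Among the measured compounds shown here, with only two measured compounds, this says little about where compound 2 sits in any wider range.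

The next compound is compound 3 `O=C(O)CC1Cc2ccc(-c3cc(F)cc(OC(F)F)c3)cc2N1S(=O)(=O)c1cccc(C(F)(F)F)c1`, which differs from compound 2 by carboxymethyl in place of hydrogen on a saturated ring carbon, next to the ring nitrogen: carboxymethyl in place of hydrogen on a saturated ring carbon.

For the measured compounds named here, only one measured step is available, a 19-fold higher number from compound 1 to compound 2 (1.27 log units; beyond the scatter). It exchanges (2-chloro-6-fluorobenzyl)oxy for 3-(difluoromethoxy)-5-fluorophenyl on an aromatic carbon, a different place from the present change. It therefore bears on this change only indirectly, showing that a single change between these two compounds can give a large step. Going by the values given here, no measured pair tests carboxymethyl itself, so the size remains uncertain.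

In this assay, a large step to a higher number is expected, of broadly similar size to that one. The estimated step is a 17-fold higher number from compound 2 to compound 3 (1.23 log units; beyond the scatter). For compound 3 the expected value is 25000 nM, with an estimated range of 6000 nM to 90000 nM.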

Compound 3, solubility: 69400 nM
Compound 3: middle estimate off by 2.8-fold (0.44 log units), on the low side; low and high end bracket the measured number.
By their numbers in this assay, from the lowest: compound 1; then compound 2; then compound 3.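

In this assay, among the compounds shown here, carboxymethyl in place of hydrogen on the saturated ring carbon next to the ring nitrogen gives a 47-fold higher number from compound 2 to compound 3 (1.67 log units; beyond the scatter), the first measured change at this position, which is unchanged between compound 1 and compound 2. Alongside a 19-fold higher number from compound 1 to compound 2 (1.27 log units; beyond the scatter), a change on an aromatic carbon, it shows that two different places on the shared core can each carry a large step to a higher number, here with the 3-(difluoromethoxy)-5-fluorophenyl of compound 2 kept in place. No measurement is available that accounts for the size of the new step.

The compounds shown leave open whether the step belongs to the carboxylic acid itself or to the added chain, a question that a methyl ester, a primary amide, an amine or a longer chain ending in a carboxylic acid on the same ring carbon would help to settle. Also open, from the compounds shown here alone, is whether carboxymethyl at this position gives a step of similar size when the (2-chloro-6-fluorobenzyl)oxy group of compound 1 replaces the 3-(difluoromethoxy)-5-fluorophenyl group.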